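Hydrazine substituent variation on the shared core

The source may hold more compounds than are shown below. What is called first, only, known or untested is meant among the compounds shown, and "the series" means these compounds.

In a functional assay on the whole organism with Mus musculus as the target, with a stated time of 1 h (a higher number here means that more compound is needed for the effect, a lower number that less compound is needed), compound 3 `Cc1ccccc1-c1nnc(N(C)NC(C)C)s1` gives 38 mg/kg. That is the lowest of the three numbers measured, yet both gaps to its neighbours fall within the scatter, so no order among them is claimed: compound 1 `Cc1ccccc1-c1nnc(N(N)C(C)C)s1` gives 49 mg/kg and compound 2 `Cc1ccccc1-c1nnc(NNC(C)C)s1` gives 54 mg/kg. The measured steps are small throughout: a 1.3-fold lower number from compound 1 to compound 3 (0.11 log units; within the scatter), a 1.4-fold lower number from compound 2 to compound 3 (0.15 log units; within the scatter) and a 1.1-fold higher number from compound 1 to compound 2 (0.04 log units; within the scatter). Compound 4 `Cc1ccccc1-c1nnc(N(C)N(C)C)s1` carries a different change, (dimethylamino in place of isopropylamino on a nitrogen on an aromatic ring). Within the data shown here, no measured step exchanges the isopropylamino itself; the nearest, the methyl-for-hydrogen steps to compound 3, stay within the scatter, so no step beyond the scatter is expected here. The expected step is a 1.2-fold higher number from compound 3 to compound 4 (0.07 log units; within the scatter). Compound 4 is therefore estimated at 45 mg/kg, with a range from 20 mg/kg to 100 mg/kg.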

Compound 4, dose for half-maximal effect: 68 mg/kg
Estimate against measurement, compound 4: 1.5-fold (0.18 log units) below, within the range that was stated.
By their numbers in this assay, from the lowest: compounds 3, 1, 2 and 4 (each within the scatter of the next).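

In this assay, dimethylamino, with 0 hydrogen-bond donors, in place of isopropylamino, with 1, on this nitrogen gives a step that stays within the scatter (a 1.8-fold higher number from compound 3 to compound 4 (0.25 log units; within the scatter)). The wider comparisons stay within the scatter too (a 1.3-fold higher number from compound 2 to compound 4 (0.10 log units; within the scatter); a 1.4-fold higher number from compound 1 to compound 4 (0.14 log units; within the scatter)), so no order is claimed and this change shows no effect beyond the scatter. No supporting measurement bears on these steps.

Still open, on these data alone, is whether a longer chain, a benzyl group or a carboxylic acid on this nitrogen would move the number beyond the scatter.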